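Adding a Methyl to a Compound Without Measurable Toxicity

The compounds below may be only part of what the source reports. "The series", "measured", "known", "first", "only" and "open" are said of these compounds alone.

Compound 1 `O=c1cc(Cc2c(F)cccc2F)nc(N2CCCCC2)[nH]1`: > 82000 nM
Compound 2 `CN1CCN(c2nc(Cc3c(F)cccc3F)cc(=O)[nH]2)CC1`: > 78000 nM

In an ADME assay on MT4 cells (Homo sapiens) for cytotoxicity, read by MTT assay, with a stated time of 4 days (on this read-out lower numbers stand for higher toxicity in this test and higher numbers for lower toxicity in this test), compound 1 reaches only a limit, > 82000 nM. Compound 2 likewise gives only a limit in this assay, > 78000 nM. For the measured compounds named here, compound 2 thus stands at a limit, and the one other value shown is a limit as well. Going by the values given here, the single measured step, a step that the two limits leave unreadable from compound 1 to compound 2, cannot be read from two limits. Compound 3 `Cc1c(Cc2c(F)cccc2F)nc(N2CCN(C)CC2)[nH]c1=O` differs from compound 2 by methyl in place of hydrogen on an aromatic carbon. Among the compounds with values here, no measured step bears on this change, and nothing in the values shown hints at toxicity emerging. Compound 3 is therefore expected to remain at a limit, with the step that the limit leaves unreadable from compound 2 to compound 3 expected to be none beyond the scatter, and an estimate of 100000 nM within 50000 nM to 300000 nM.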

Compound 3, half-maximal cytotoxic concentration: > 75000 nM
Compound 3 ended at the assay's limit (the forecaster's own chance of this, stated with the estimate: 85%); the middle value lies beyond the limit too.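

For the compounds shown here, compound 2 and compound 3 both stop at a limit in this assay, so no step between them can be read. The compounds shown leave open at what concentration any of them would harm these cells.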